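This account rests on a few compounds, and the source may have more. Where it says the series, first, only, none or still open, it means among the compounds named here.

In a functional assay on MCF7 cells (Homo sapiens) for inhibition, read by MTT assay, with a stated time of 72 h (a higher number here means a weaker inhibitor, a lower number a stronger inhibitor), compound 1 `COc1cc2c(Oc3ccc(NC(=O)c4nn(-c5ccc(C)cc5C)cc(C)c4=O)cc3)ccnc2cc1OCCCCCCC(=O)NO` gives 2430 nM and compound 2 `COc1cc2c(Oc3ccc(NC(=O)c4nn(-c5ccc(C)cc5)cc(C)c4=O)cc3)ccnc2cc1OCCCCCCC(=O)NO` gives 2560 nM. For the measured compounds named here, these two values lie within the scatter of each other, so compound 2 stands level with the only other measured compound. Compound 3 `COc1cc2c(Oc3ccc(NC(=O)c4nn(-c5ccccc5)cc(C)c4=O)cc3)ccnc2cc1OCCCCCCC(=O)NO` differs from compound 2 by one change, 4-methylphenyl to phenyl: hydrogen in place of methyl on an aromatic carbon. Going by the values given here, only one measured step bears on this change: a 1.1-fold higher number from compound 1 to compound 2 (0.02 log units; within the scatter). That step is also hydrogen in place of methyl on an aromatic carbon, though not at the same place, and it stays within the scatter. On this single precedent, no step beyond the scatter is expected in this assay, and no direction can be favoured. The expected step is a 1.0-fold higher number from compound 2 to compound 3 (0.01 log units; within the scatter). For compound 3 the estimated value is 2600 nM, with an expected range of 1400 nM to 4800 nM.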

Compound 3, half-maximal inhibitory concentration: 1610 nM
Compound 3: middle estimate off by 1.6-fold (0.21 log units), on the high side, within the range that was stated.
By their numbers in this assay, from the lowest: compounds 3, 1 and 2 (each within the scatter of the next).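

In this assay the 4-methylphenyl to phenyl replacement, on an aromatic carbon para to a large group, now has its own reading: a 1.6-fold lower number from compound 2 to compound 3 (0.20 log units; within the scatter). With phenyl in place of 2,4-dimethylphenyl on the aromatic nitrogen, the reading is a 1.5-fold lower number from compound 1 to compound 3 (0.18 log units; within the scatter), so neither methyl group, alone or with the other, takes the series outside the scatter, and these three compounds stand level. Nothing available on these compounds offers an explanation for these readings.

Still open, going by these compounds, is whether a chlorine, a methoxy group or an amine at this same place would give a step beyond the scatter. With no such step among the compounds shown, how far this position can move the number in this assay remains unknown.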